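A few compounds are considered here, and "the series" means these few. Any claim that something is new, unique, unknown or untested is made for them only; others in the source may bear on it.

Among the compounds with values here, in a functional assay on HeLa cells (Homo sapiens) for antiproliferative activity, read by cell counting, with a stated time of 72 h (on this read-out higher numbers stand for weaker inhibition and lower numbers for stronger inhibition), compound 3 (`C#C[C@@]1(O)[C@@H](CO)O[C@@H](n2cc(F)c3c(N)ncnc32)[C@@H]1O`) gives 150 nM as the only actual number so far. Compound 1 (`C#C[C@@]1(O)[C@@H](CO)O[C@@H](n2cnc3c(-c4ccccc4)ncnc32)[C@@H]1O`) gives > 250000 nM as a limit of the assay. Compound 2 (`C#C[C@@]1(O)[C@@H](CO)O[C@@H](n2cnc3c(-c4ccc(OC)cc4)ncnc32)[C@@H]1O`) gives > 250000 nM as a limit as well. The remaining values are therefore not numbers (the limit of > 250000 nM in this assay, at which 2 of the 3 values shown sit), and compound 3 has nothing measured to rank against except these limits.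

Compound 4 (`C#C[C@@]1(O)[C@@H](CO)O[C@@H](n2cc(-c3ccco3)c3c(N)ncnc32)[C@@H]1O`) differs from compound 3 by one change (furan-2-yl in place of fluoro on an aromatic carbon): furan-2-yl in place of fluoro on an aromatic carbon of a five-membered aromatic ring with 1 nitrogen. Within the data shown here, the only measured step (a step that the two limits leave unreadable from compound 1 to compound 2) has no readable size and belongs to a different core, so no measured step sizes this change directly. Among the measured compounds shown here, the one indirect hint is compound 1, which carries an aromatic ring on its own core and gives > 250000 nM as a limit, so some loss is expected on replacing fluoro with furan-2-yl, although the difference in core keeps this loose. The expected step in this assay is a 10-fold higher number from compound 3 to compound 4 (1.00 log units; beyond the scatter) towards weaker inhibition, with wide uncertainty. Compound 4 is estimated at 1500 nM within an expected range from 100 nM to 30000 nM for now.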

Compound 4, half-maximal inhibitory concentration: 14000 nM
Compound 4: middle estimate off by 9.3-fold (0.97 log units), on the low side; low and high end bracket the measured number.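

In this assay, the place two ring bonds from the ring nitrogen proves sensitive to the group it carries: furan-2-yl in place of fluoro gives a 93-fold higher number from compound 3 to compound 4 (1.97 log units; beyond the scatter), towards weaker inhibition. Within the data shown here, this is the first readable step, and compound 4, at 14000 nM, still gives an actual number, so on this core an added five-membered aromatic ring weakens inhibition. Nothing shown accounts for the size of this loss.

With only fluoro and furan-2-yl at this place, the compounds shown do not tell where other groups, such as a nitrile, an amine, a methyl or a phenyl, would fall on the shared core, or whether the furan oxygen matters at all. The only other step, on the core of compound 1, cannot be read, which leaves no second measured change to set beside this one: the limit of > 250000 nM in this assay, at which 2 of the 4 values shown sit.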